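A few compounds are considered here, and "the series" means these few. Any claim that something is new, unique, unknown or untested is made for them only; others in the source may bear on it.

In a functional assay on A549 cells (Homo sapiens) for antiproliferative activity, read by CCK-8 assay, with a stated time of 72 h (on this read-out lower numbers stand for stronger inhibition and higher numbers for weaker inhibition), compound 1 (`Cc1cc(Nc2cc(N3CCN(C)CC3)nc(Nc3ccc([N+](=O)[O-])cc3)n2)n[nH]1`) gives 723 nM and compound 2 (`Cc1cc(Nc2cc(N3CCN(C)CC3)nc(Nc3cccc([N+](=O)[O-])c3)n2)n[nH]1`) gives 926 nM. With only these two compounds measured, compound 2 stands level with compound 1, and the gap between them lies within the normal scatter of repeated measurements. That gap is a 1.3-fold higher number from compound 1 to compound 2 (0.11 log units; within the scatter), and it comes from 3-nitrophenyl in place of 4-nitrophenyl on a nitrogen on an aromatic ring.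

Compound 3 (`Cc1cc(Nc2cc(N3CCN(C)CC3)nc(Nc3ccc(C#N)cc3)n2)n[nH]1`) keeps the shared core and changes the group at that same place: 4-cyanophenyl in place of 3-nitrophenyl on a nitrogen on an aromatic ring. In words, this is 4-cyanophenyl in place of 3-nitrophenyl on a nitrogen on an aromatic ring.

Among the compounds with values here, the single measured step at this place, a 1.3-fold higher number from compound 1 to compound 2 (0.11 log units; within the scatter), is the only guide, and it is an indirect one, as no measured compound carries 4-cyanophenyl. A step beyond the scatter is therefore not expected in this assay, and no clear direction can be argued. The expected change is a 1.2-fold lower number from compound 2 to compound 3 (0.06 log units; within the scatter). The estimated value for compound 3 is 800 nM, with an expected range of 300 nM to 2100 nM.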

Compound 3, half-maximal inhibitory concentration: 785 nM
For compound 3 the middle estimate is 1.0-fold (0.01 log units) above the measured one; the range from low to high includes it.
By their numbers in this assay, from the lowest: compounds 1, 3 and 2 (each within the scatter of the next).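

In this assay, this position now has a second kind of group on its phenyl ring, rather than only the nitro group in two placements: 4-cyanophenyl in place of 3-nitrophenyl gives a 1.2-fold lower number from compound 2 to compound 3 (0.07 log units; within the scatter), and cyano in place of nitro on an aromatic carbon gives a 1.1-fold higher number from compound 1 to compound 3 (0.04 log units; within the scatter). The nitro group is therefore not required for activity at this level in this assay, as compound 3 carries none and still stands level with compound 1 and compound 2. No measured evidence is available that could explain why these three compounds stand level.

As far as these compounds go, each of the three compounds has a nitro or nitrile group on the phenyl ring, so it remains open whether the same level would hold for an unsubstituted phenyl, or for a phenyl carrying an amine, a carboxylic acid or a methoxy group. The rest of the shared core is the same in compound 1, compound 2 and compound 3, so these values say nothing about changes made anywhere else on the molecule.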